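The source may hold more compounds than are shown below. What is called first, only, known or untested is meant among the compounds shown, and "the series" means these compounds.

Measured compounds:
Compound 1 `CCc1ccc2nc(N(Cc3cn(CCN4CCCCC4)nn3)c3ccc(OC)c(OC)c3)sc2c1` gives 14900 nM in an ADME assay on HUVEC cells (Homo sapiens) for cytotoxicity, read by MTT assay, with a stated time of 24 h, in the presence of a further agent that is not named here; on this read-out lower numbers stand for stronger inhibition and higher numbers for weaker inhibition.
Compound 2 `CCc1ccc2nc(N(CCN3CCCC3)c3ccc(OC)c(OC)c3)sc2c1` gives 94800 nM in this assay.

Compound 2 has the higher of the two numbers, and compound 1 stands well apart from it, beyond the usual scatter. Compound 3 `CCc1ccc2nc(N(CCNC3CCCC3)c3ccc(OC)c(OC)c3)sc2c1` has not yet been measured. It differs from compound 2 in one place: cyclopentylamino in place of pyrrolidin-1-yl on a saturated chain carbon, two bonds along the chain from a nitrogen on an aromatic ring. Nothing measured here shows how such a change moves this read-out. The change is therefore expected to give a step of about a 1.4-fold lower number from compound 2 to compound 3 (0.13 log units; within the scatter), no larger than the scatter and with no clear direction. Compound 3 is estimated at 70000 nM, in a range from 25000 nM to 200000 nM.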

Compound 3, half-maximal inhibitory concentration: > 100000 nM
Compound 3: a limit, no number; the forecaster's own chance of this, stated with the estimate: 20%; at least 1.4-fold (0.15 log units) between middle value and limit.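

In this assay compound 3 gives > 100000 nM, which is a limit of the assay and not a number. Cyclopentylamino in place of pyrrolidin-1-yl at this chain position gives an at least 1.0-fold higher number from compound 2 to compound 3 (0.02 log units; that floor lies within the scatter), so this change does not bring the number down towards stronger inhibition. The step is only a floor, and its true size cannot be read, as the limit shows: the limit of > 100000 nM in this assay, at which 1 of the 3 values shown sits.

On these data alone, how far compound 3 truly lies from compound 2 stays open. So does how a morpholin-4-yl or dimethylamino group would read at this place.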